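This account rests on a few compounds, and the source may have more. Where it says the series, first, only, none or still open, it means among the compounds named here.

For the measured compounds named here, compound 1 `NC(=O)CCCCc1c[nH]c2ccc(F)cc12` is the only member of the set with a numerical result: in an assay on isolated protein for inhibition of Myeloperoxidase (Homo sapiens), read by ELISA, with a stated time of 5 min (a higher number here means a weaker inhibitor, a lower number a stronger inhibitor), compound 1 gives 43 nM. Compound 2 `NCCSCCCc1c[nH]c2c(F)cccc12` reaches only (the limit of > 100 nM in this assay, at which 1 of the 2 values shown sits); in this assay compound 2 gives > 100 nM, which is a limit of the method and not a number. Compound 3 `N#CSCCCc1c[nH]c2ccc(F)cc12` has not been measured; it differs from compound 1 by cyanosulfanyl in place of carbamoylmethyl on a saturated chain carbon, three bonds along the chain from an aromatic carbon. Going by the values given here, no step between measured compounds exists to size this change, so the expectation is a modest loss beyond the scatter, a 2.3-fold higher number from compound 1 to compound 3 (0.37 log units; beyond the scatter), with a real chance that the result comes back as a limit. Compound 3 is estimated at 100 nM, between 30 nM and 400 nM.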

Compound 3, half-maximal inhibitory concentration: 23 nM
For compound 3 the middle estimate is 4.3-fold (0.64 log units) above the measured one; the whole stated range lies above it.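

The step in this assay reads a 1.9-fold lower number from compound 1 to compound 3 (0.27 log units; within the scatter), so on a saturated chain carbon, three bonds along the chain from an aromatic carbon, cyanosulfanyl can stand in place of carbamoylmethyl without a change that can be told from the scatter. Compound 3 has no hydrogen-bond donor in this group, so the donor of carbamoylmethyl is not needed for a value in this range. Nothing shown here explains the step. As far as these compounds go, whether a carboxylic acid, an amine or a longer chain at this place stays in the same range remains open.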